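A few compounds are considered here, and "the series" means these few. Any claim that something is new, unique, unknown or untested is made for them only; others in the source may bear on it.

Measured so far in an ADME assay on Vero cells (Chlorocebus sabaeus) for cytotoxicity, read by MTT assay, with a stated time of 72 h; on this read-out higher numbers stand for lower toxicity in this test and lower numbers for higher toxicity in this test:
- compound 1 `COc1ccc(/C=C/C(=O)NCCNc2ccnc3cc(Cl)ccc23)cc1`: 20600 nM
- compound 2 `O=C(/C=C/c1ccco1)NCCNc1ccnc2cc(Cl)ccc12`: 629000 nM

Compound 2 holds the highest of the two numbers in this assay; its nearest neighbour is compound 1, separated by a 31-fold higher number from compound 1 to compound 2 (1.48 log units; beyond the scatter). That single step is the only one available, and it concerns the same position on the chain as the step now considered: swapping the 4-methoxyphenyl of compound 1 for the furan-2-yl of compound 2 gave a large rise.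

Compound 3 `O=C(/C=C/c1ccc(Cl)cc1)NCCNc1ccnc2cc(Cl)ccc12` differs from compound 2 by 4-chlorophenyl in place of furan-2-yl on a double-bonded chain carbon bound to a double-bonded chain carbon. The change puts a six-membered carbon ring back at the place where the step to compound 2 removed one, so the relevant precedent is the step from compound 1 to compound 2 run in reverse. On that basis a large drop in this assay is expected for compound 3, of about a 16-fold lower number from compound 2 to compound 3 (1.20 log units; beyond the scatter), landing in the neighbourhood of compound 1 rather than that of compound 2. Whether the 4-chloro substituent behaves exactly like the 4-methoxy group is not known from these two compounds, so the range is kept wide. The estimate for compound 3 in this assay is 40000 nM, with a range from 10000 nM to 200000 nM.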

Compound 3, half-maximal cytotoxic concentration: 6930 nM
Estimate against measurement, compound 3: 5.8-fold (0.76 log units) above, outside the stated range (below it).
By their numbers in this assay, from the lowest: compound 3; then compound 1; then compound 2.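

In this assay, the six-membered carbon ring proves decisive in both directions at this place on the chain: 4-chlorophenyl in place of furan-2-yl gives a 91-fold lower number from compound 2 to compound 3 (1.96 log units; beyond the scatter) and so joins the earlier 31-fold higher number from compound 1 to compound 2 (1.48 log units; beyond the scatter) in leaving compound 2 alone at the high end of the three. The substituent on that ring also counts, since chloro in place of methoxy on an aromatic carbon gives a 3.0-fold lower number from compound 1 to compound 3 (0.47 log units; beyond the scatter) as a step beyond the scatter, though only a modest one, so the choice of ring covers most of the range seen here and the ring substituent a smaller part. Nothing available here bears on why these numbers differ.

Still open, from the compounds shown here alone, is whether the high number belongs to furan-2-yl itself or extends to other rings at this place, such as thiophen-2-yl, pyridin-3-yl or an unsubstituted phenyl, which could side with either compound 2 or compound 3. Also open, going by these compounds, is whether the same ordering of these three groups would hold with a longer chain joining the amide to the shared core, or with an amine or a carboxylic acid on the six-membered ring.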